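Adding a Branched Chain to a Bis-Indole Quinone

The compounds below may be only part of what the source reports. "The series", "measured", "known", "first", "only" and "open" are said of these compounds alone.

Measured compounds:
- Compound 1, `CC1(C)C[C@]23[C@@H](C(=O)O)CC[C@H]1[C@@H]2CC(=O)[C@@H]3CO`: 7800 nM
- Compound 2, `COC1=C(c2c[nH]c3ccccc23)C(=O)C(OC)=C(c2c[nH]c3ccccc23)C1=O`: 15800 nM

Both were tested in a functional assay on SF-268 cells (Homo sapiens) for cytotoxicity, read by MTT assay, with a stated time of 48 h; a higher number here means a weaker inhibitor, a lower number a stronger inhibitor. Compound 1 gives 7800 nM. Compound 2 gives 15800 nM, the highest of the two numbers, and the gap to compound 1 is beyond the usual scatter, so compound 2 is the weaker inhibitor of the two.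

Compound 3, `C=CC(C)(C)c1[nH]c2ccccc2c1C1=C(OC)C(=O)C(c2c[nH]c3ccccc23)=C(OC)C1=O`, is built from compound 2 by one change: 1,1-dimethylprop-2-en-1-yl in place of hydrogen on an aromatic carbon.

Among the compounds with values here, no pair of measured compounds shows what this kind of change does, so no step size can be read off. With nothing to lean on, a small step is expected, if any, and it is estimated to be a 1.6-fold lower number from compound 2 to compound 3 (0.20 log units; within the scatter), roughly within the scatter. Compound 3 is therefore expected to give about 10000 nM, likely between 3000 nM and 30000 nM.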

Compound 3, half-maximal inhibitory concentration: 25700 nM
Beside the measured number, compound 3's estimate is 2.6-fold (0.41 log units) below it; the range from low to high includes it.
By their numbers in this assay, from the lowest: compound 1; then compounds 2 and 3 (each within the scatter of the next).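

In this assay, 1,1-dimethylprop-2-en-1-yl in place of hydrogen gives a 1.6-fold higher number from compound 2 to compound 3 (0.21 log units; within the scatter), so compound 2 and compound 3 cannot be told apart. Within the data shown here, this is the first sign that an aromatic carbon next to the ring nitrogen, and next to the ring atom that bears a large group, can carry this branched chain of 5 carbon atoms without a step beyond the scatter. Nothing available explains why the step is this size.

From the compounds shown here alone, whether a small methyl group, an amine or a carboxylic acid at the same position would give a step beyond the scatter remains open. Also open, going by these compounds, is what a second 1,1-dimethylprop-2-en-1-yl elsewhere on the shared core would do.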